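Swapping the aryl ether end: compound 3 to compound 4

A few compounds are considered here, and "the series" means these few. Any claim that something is new, unique, unknown or untested is made for them only; others in the source may bear on it.

The three measured compounds share one core and differ in the group that sits on an oxygen on an aromatic ring. Compound 1 `CCCc1nc2ccccc2c(=O)n1/N=C/c1ccc(Oc2ccc3ccccc3c2)cc1` gives 6.12 in a physicochemical assay for lipophilicity, in phosphate buffer, measured as octanol-water partition; a lower number here means a more polar compound, a higher number a more lipophilic compound. Compound 2 `O=c1c2ccccc2nc(-c2ccccc2)n1/N=C/c1ccc(Oc2ccc([N+](=O)[O-])cc2)cc1` gives 6.12 in this assay. Compound 3 `CCCc1nc2ccccc2c(=O)n1/N=C/c1ccc(Oc2ccc(Cl)c(C)c2)cc1` gives 6.02 in this assay; this is the smallest of the three numbers, yet both of the others lie within the scatter of it. For the measured compounds named here, the single measured step that changes only this group, a number 0.10 log units lower from compound 1 to compound 3 (within the scatter), shows that exchanging the aryl group on the oxygen barely moved the number.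

Compound 4 `CCCc1nc2ccccc2c(=O)n1/N=C/c1ccc(Oc2ccc([N+](=O)[O-])cc2)cc1` has not yet been measured. It differs from compound 3 in one place: 4-nitrophenyl in place of 4-chloro-3-methylphenyl on an oxygen on an aromatic ring. Going by the values given here, the step from compound 1 to compound 3 is the only measured step at this position, and it stayed within the scatter. Compound 2, which carries the same 4-nitrophenyl group on a different core, gives a number within the scatter of compound 3. On this basis the step to compound 4 is expected to be a number 0.12 log units lower from compound 3 to compound 4 (within the scatter), not beyond the scatter. The estimate for compound 4 is 5.9, with a range from 5.3 to 6.3.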

Compound 4, partition coefficient: 5.18
Compound 4: middle estimate off by 0.72 log units, on the high side; the whole stated range lies above it.
By their numbers in this assay, from the lowest: compound 4; then compounds 3, 1 and 2 (each within the scatter of the next).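

Across the propyl compounds, the group on the oxygen is not as free to change as the earlier step suggested: a number 0.10 log units lower from compound 1 to compound 3 (within the scatter) in this assay had left naphthalen-2-yl and 4-chloro-3-methylphenyl unseparated, but 4-nitrophenyl stands apart from both, with a number 0.84 log units lower from compound 3 to compound 4 (beyond the scatter) and a number 0.94 log units lower from compound 1 to compound 4 (beyond the scatter) as the two steps that show it. The other end of the molecule also counts, since with 4-nitrophenyl kept in place, propyl in place of phenyl on an aromatic carbon gives a number 0.94 log units lower from compound 2 to compound 4 (beyond the scatter) and the same aryl ether group therefore does not fix the number on its own. Nothing available explains either shift.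

The compounds shown leave open whether the shift belongs to the nitro group in particular or would also appear with a nitrile or a methoxy group in its place on the ring. They also leave open how a chain longer than propyl, or an amine on that aromatic carbon, would behave with 4-nitrophenyl on the oxygen.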